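From Benzyl to Phenyl on the Shared Core

The source may hold more compounds than are shown below. What is called first, only, known or untested is meant among the compounds shown, and "the series" means these compounds.

In a functional assay on HeLa cells (Homo sapiens) for inhibition, read by cell counting, with a stated time of 4 days (on this read-out higher numbers stand for weaker inhibition and lower numbers for stronger inhibition), compound 2 `C=C(Br)C(=O)Nc1cccc(-c2cn3nc(Cc4ccc(Cl)cc4)sc3n2)c1` gives 2700 nM, and compound 1 `C=C(Br)C(=O)Nc1cccc(-c2cn3nc(Cc4cccc(OC)c4)sc3n2)c1` gives 2500 nM; these two values lie within the usual scatter of each other, as the step of a 1.1-fold higher number from compound 1 to compound 2 (0.03 log units; within the scatter) shows. Compound 3 `C=C(Br)C(=O)Nc1cccc(-c2cn3nc(-c4cccc(OC)c4)sc3n2)c1` differs from compound 2 by 3-methoxyphenyl in place of 4-chlorobenzyl on an aromatic carbon. Going by the values given here, the one measured step that bears on this, a 1.1-fold higher number from compound 1 to compound 2 (0.03 log units; within the scatter), exchanged the same two aromatic groups while keeping the saturated chain carbon, and changed nothing beyond the scatter. Among the compounds with values here, no measured pair shows removal of that chain carbon. For compound 3 the expected step is a 1.1-fold lower number from compound 2 to compound 3 (0.03 log units; within the scatter), nothing beyond the scatter. Compound 3 is therefore estimated at 2500 nM, with a range from 800 nM to 8000 nM.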

Compound 3, half-maximal inhibitory concentration: 1100 nM
Compound 3: middle estimate off by 2.3-fold (0.36 log units), on the high side, within the range that was stated.
By their numbers in this assay, from the lowest: compound 3; then compounds 1 and 2 (each within the scatter of the next).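

In this assay the clearest view of the saturated chain carbon is a 2.3-fold lower number from compound 1 to compound 3 (0.36 log units; beyond the scatter) with the 3-methoxyphenyl ring kept and only that carbon gone. The step of a 2.5-fold lower number from compound 2 to compound 3 (0.39 log units; beyond the scatter) is also modest, although it changes the ring substituent as well. Unlike the earlier exchange of one benzyl group for another, these steps show that this position responds when the phenyl ring sits directly on the shared core. Nothing available explains this stronger inhibition. Going by these compounds, whether a two-carbon chain, or an amine on the phenyl ring of compound 3, would keep it remains open.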